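A few compounds are considered here, and "the series" means these few. Any claim that something is new, unique, unknown or untested is made for them only; others in the source may bear on it.

In an ADME assay on MT4 cells (Homo sapiens) for cytotoxicity, read by MTT assay, with a stated time of 5 days; on this read-out higher numbers stand for lower toxicity in this test and lower numbers for higher toxicity in this test:
- compound 1 `Cc1cc(C)cc(S(=O)(=O)c2c(C(=O)N[C@@H]3CCN(Cc4n[nH]c(=O)n4C)C3)[nH]c3ccc(Cl)cc23)c1`: 22400 nM
- compound 2 `Cc1cc(C)cc(S(=O)(=O)c2c(C(=O)N[C@@H]3CCN(Cc4ccccc4F)C3)[nH]c3ccc(Cl)cc23)c1`: > 231000 nM (a limit)
- compound 3 `Cc1cc(C)cc(S(=O)(=O)c2c(C(=O)N[C@@H]3CCN(CC(N)=O)C3)[nH]c3ccc(Cl)cc23)c1`: 31000 nM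

Compound 3 cannot be told apart from compound 1: a 1.4-fold higher number from compound 1 to compound 3 (0.14 log units; within the scatter). Compound 4 `Cc1cc(C)cc(S(=O)(=O)c2c(C(=O)NC3CN(Cc4ccccc4F)C3)[nH]c3ccc(Cl)cc23)c1` differs from compound 3 as follows: 1-(2-fluorobenzyl)azetidin-3-yl in place of 1-(carbamoylmethyl)pyrrolidin-3-yl on an amide-type nitrogen. It thus shares the 2-fluorophenyl group of compound 2. Within the data shown here, two measured steps bear on this: an at least 7.4-fold lower number from compound 2 to compound 3 (0.87 log units; beyond the scatter) and an at least 10-fold higher number from compound 1 to compound 2 (1.01 log units; beyond the scatter). Both are beyond the scatter, and both put the compound with that group on the higher side. Among the measured compounds shown here, no measured compound shows the four-membered ring, so a smaller step in the same direction is expected. The expected change is a 2.3-fold higher number from compound 3 to compound 4 (0.35 log units; beyond the scatter). For compound 4 the estimated value in this assay is 70000 nM, with an expected range of 18000 nM to 260000 nM.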

Compound 4, half-maximal cytotoxic concentration: > 238000 nM
Compound 4: only a limit was reported; the forecaster's own chance of this, stated with the estimate: 40%; middle value at least 3.4-fold (0.53 log units) away from the limit.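

In this assay, the exchange on the amide-type nitrogen gives an at least 7.6-fold higher number from compound 3 to compound 4 (0.88 log units; beyond the scatter), so the 2-fluorophenyl group stays on the higher side when carried on a four-membered ring, which the pyrrolidin-3-yl compounds could not show. Compound 4 gives > 238000 nM, which is a limit. Compound 2 also stands at a limit, so the two ring sizes cannot be ranked.

Going by these compounds, this step changes ring and side group together, and their separate shares remain unknown. Open too, on these data alone, is how 1-(carbamoylmethyl)azetidin-3-yl, or a plain benzyl without fluorine on the azetidine, would read.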